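This account rests on a few compounds, and the source may have more. Where it says the series, first, only, none or still open, it means among the compounds named here.

Working notes on the sulfonamide series in a functional assay on 3T3-L1 cells (Mus musculus) for inhibition, with a stated time of 20 min, tested at 20 uM; on this read-out lower numbers stand for less inhibition and higher numbers for more inhibition at the one concentration tested (going by the name of the read-out).

Of the compounds shown here, three have numbers so far. Compound 1 `O=S(=O)(c1ccc(F)cc1)N(Cc1ccccc1)Cc1cccc(F)c1F` gives -81.9% in this assay. Compound 3 `O=C(N(Cc1cccc(F)c1F)Cc1cn(S(=O)(=O)c2ccc(F)cc2)c2ccccc12)C(F)(F)F` gives -52.3% in this assay. Compound 2 `Cc1ccc(S(=O)(=O)n2c(CN(Cc3cn(Cc4ccc(F)cc4F)nn3)S(C)(=O)=O)c(C)c3ccccc32)cc1` gives -20.8% in this assay, and stands highest of the three: its number lies beyond the scatter above that of compound 3, and further still above that of compound 1. No two of these compounds differ in only one place, so no single step between measured compounds can be read off.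

Compound 4 `Cc1ccc(S(=O)(=O)N(Cc2cn(Cc3ccc(F)cc3F)nn2)Cc2c(C)c3ccccc3n2S(=O)(=O)c2ccc(C)cc2)cc1` differs from compound 2 in one place: 4-methylphenyl in place of methyl on a sulfonyl sulfur. The change is methylsulfonyl to (4-methylphenyl)sulfonyl on a sulfonyl sulfur whose other neighbour is the sulfonamide nitrogen; the rest of the molecule is kept.

Among the measured compounds shown here, nothing among the measured compounds isolates this change, so the direction is open. The step from compound 2 to compound 4 is expected to stay within the scatter, a number 0.8 percentage points higher from compound 2 to compound 4 (within the scatter). Compound 4 is therefore expected to give about -20% in this assay, with a range from -60% to 20%.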

Compound 4, a percentage reported as inhibition, at one concentration (the size of the read-out at that concentration, not a potency): -22%
Beside the measured number, compound 4's estimate is 2 percentage points above it, within the range that was stated.
By their numbers in this assay, from the lowest: compound 1; then compound 3; then compounds 4 and 2 (each within the scatter of the next).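

In this assay, 4-methylphenyl in place of methyl on a sulfonyl sulfur whose other neighbour is the sulfonamide nitrogen gives a number 1.2 percentage points lower from compound 2 to compound 4 (within the scatter). Among the compounds shown here, this is the first single-place step, and it shows that a six-membered aromatic ring of carbon only can enter at this position without the read-out separating the two compounds. No measured property or other evidence bears on this result.

The compounds shown leave open whether an amine or a carboxylic acid on this sulfonyl sulfur would leave the read-out equally unmoved, and whether a longer chain would do the same. Compound 1 and compound 3 differ from these two in more than one place, so their values cannot be read as steps at this position.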